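Thioester truncation in the glutamyl-cysteamine series

A few compounds are considered here, and "the series" means these few. Any claim that something is new, unique, unknown or untested is made for them only; others in the source may bear on it.

Measured so far:
- compound 1 `CCOC(=O)[C@@H](N)CCC(=O)NCCSC(=O)C(C)(C)C`: 228000 nM
- compound 2 `CCCCOC(=O)[C@@H](N)CCC(=O)NCCSC(=O)C(C)(C)C`: 102000 nM
- compound 3 `CCCOC(=O)[C@@H](N)CCC(=O)NCCSC(=O)C(C)(C)C`: 152000 nM

In an ADME assay on HaCaT cells (Homo sapiens) for cytotoxicity, read by MTT assay, with a stated time of 48 h (a lower number here means that less compound is needed, a higher number that more compound is needed for the effect), compound 1 gives the highest number of the three. Its nearest neighbour is compound 3, with a 1.5-fold lower number from compound 1 to compound 3 (0.18 log units; within the scatter); the step to compound 2 is larger, a 2.2-fold lower number from compound 1 to compound 2 (0.35 log units; beyond the scatter). Between compound 2 and compound 3 the difference is a 1.5-fold higher number from compound 2 to compound 3 (0.17 log units; within the scatter).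

Compound 4 `CCOC(=O)[C@@H](N)CCC(=O)NCCSC(C)=O` is the next compound to be measured. It differs from compound 1 in one place: methyl in place of tert-butyl on a carbonyl carbon

For the measured compounds named here, none of the measured steps touches the carbonyl carbon next to sulfur; all three lie on the ester side of the shared core. They show that adding ethyl there gives a modestly lower number, a 2.2-fold lower number from compound 1 to compound 2 (0.35 log units; beyond the scatter), while adding methyl stays within the scatter, a 1.5-fold lower number from compound 1 to compound 3 (0.18 log units; within the scatter). The change to compound 4 runs the other way, removing carbons rather than adding them, so in this assay a small step towards a higher number, or none beyond the scatter, is the expectation.

Compound 4 is therefore estimated at 300000 nM, with a range of 150000 nM to 600000 nM, which means an expected step of a 1.3-fold higher number from compound 1 to compound 4 (0.12 log units; within the scatter).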

Compound 4, half-maximal effective concentration: 1730000 nM
For compound 4 the middle estimate is 5.8-fold (0.76 log units) below the measured one, and the stated range ends below it.
By their numbers in this assay, from the lowest: compounds 2, 3 and 1 (each within the scatter of the next, the first and the last beyond it); then compound 4.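

In this assay, the carbonyl carbon whose other neighbour is sulfur proves to be a sensitive place in the series: a 7.6-fold higher number from compound 1 to compound 4 (0.88 log units; beyond the scatter). That step is larger than any on the ester side, where the largest is a 2.2-fold lower number from compound 1 to compound 2 (0.35 log units; beyond the scatter), so compound 4 has the highest number of the four, and the exchange of tert-butyl for methyl moves the read-out much further than the chain changes do. No measurement shown accounts for this shift, so it stands as an observation on this single pair.

As far as these compounds go, with only tert-butyl and methyl on this carbonyl carbon, it remains open whether the number follows the carbon count of the group, and ethyl, isopropyl or phenyl there could land anywhere relative to compound 1 and compound 4. Also open, from the compounds shown here alone, is whether the same exchange gives a step of similar size on the longer chains of compound 2 and compound 3, and how a free carboxylic acid in place of the ester would read in this assay.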